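A Phenyl Added to a Series Resting at the Limit

A few compounds are considered here, and "the series" means these few. Any claim that something is new, unique, unknown or untested is made for them only; others in the source may bear on it.

Compound 1, `Cc1cc(C)cc(C(=O)N(CCCCCC(=O)Nc2ccccc2N)CC(=O)NCc2ccccc2)c1`, was tested in an assay on Sf9 cells for inhibition of protein deacetylase HDAC6 (Homo sapiens), read by fluorescence, with a stated time of 90 min; on this read-out lower numbers stand for stronger inhibition and higher numbers for weaker inhibition. In this assay compound 1 gives > 10000 nM, which is a limit of the assay and not a number. Compound 2, `Cc1cc(C)cc(CNC(=O)CN(CCCCCC(=O)Nc2ccccc2N)C(=O)c2cc(C)cc(C)c2)c1`, gives > 10000 nM, again a limit. Compound 3, `COc1ccc(CNC(=O)CN(CCCCCC(=O)Nc2ccccc2N)C(=O)c2cc(C)cc(C)c2)cc1`, gives > 10000 nM, also a limit. Because all three sit at the limit of > 10000 nM in this assay, at which 3 of the 3 values shown sit, none of the steps among them can be read: a step that the two limits leave unreadable from compound 1 to compound 2, a step that the two limits leave unreadable from compound 1 to compound 3 and a step that the two limits leave unreadable from compound 2 to compound 3 all remain of unknown size, and compound 1 can be placed only at that limit, not set above or below the others.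

Compound 4, `Cc1cc(C)cc(C(=O)N(CCCCCC(=O)Nc2cc(-c3ccccc3)ccc2N)CC(=O)NCc2ccccc2)c1`, has not yet been measured. It differs from compound 1 by phenyl in place of hydrogen on an aromatic carbon. For the measured compounds named here, none of the measured steps touch this part of the molecule; they changed only the group on the saturated chain carbon bound to the amide-type nitrogen, and even those steps could not be sized. So nothing measured speaks for or against a change in this assay. Compound 4 is expected to show a number no higher from compound 1 to compound 4 (the limit leaves the size open), that is, no step beyond the scatter. Compound 4 is therefore estimated to give 10000 nM, within a range of 2000 nM to 40000 nM, and will most likely be reported once more only as a limit.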

Compound 4, half-maximal inhibitory concentration: > 10000 nM
Compound 4: no number, only a limit (the forecaster's own chance of this, stated with the estimate: 70%); the middle value lies on the limit itself.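

In this assay compound 4 gives > 10000 nM, which is a limit and not a number. The change from compound 1 to compound 4 cannot be sized, because both compounds rest at the same limit: the limit of > 10000 nM in this assay, at which 4 of the 4 values shown sit. The compounds shown leave open whether phenyl in place of hydrogen changes inhibition at all, and how the four compounds rank against one another.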